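The source may report more compounds than this note shows. Statements on the series, on what has been measured and on what is new or still open speak of the compounds shown alone.

Measured so far:
Compound 1 `O=C1C=CC[C@H]([C@@H](O)[C@H](Cl)c2ccccc2)O1`: 4.87 ug/mL
Compound 2 `CO[C@H](c1ccccc1)[C@H](O)[C@H]1CC=CC(=O)O1`: 240 ug/mL

In a functional assay on HONE1 cells (Homo sapiens) for cytotoxicity (on this read-out higher numbers stand for weaker inhibition and lower numbers for stronger inhibition), compound 2 holds the higher of the two numbers, and so is the weaker inhibitor. Compound 3 `CC(=O)O[C@H](c1ccccc1)[C@H](O)[C@H]1CC=CC(=O)O1` differs from compound 2 by methoxy to acetoxy, that is, acetyl in place of methyl on an oxygen on a saturated carbon. Among the compounds with values here, only one measured step bears on this change: a 49-fold higher number from compound 1 to compound 2 (1.69 log units; beyond the scatter). Within the data shown here, this large step introduced the methoxy group, but no measured compound before compound 3 carries acetyl, so the evidence is indirect. With compound 2 at 240 ug/mL, the top of the numbers seen so far, a move to a lower number in this assay is expected, though a smaller one than that large step. The expected step is a 6.0-fold lower number from compound 2 to compound 3 (0.78 log units; beyond the scatter). For compound 3 the estimated value is 40 ug/mL, with an expected range from 6 ug/mL to 240 ug/mL.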

Compound 3, half-maximal inhibitory concentration: 6.09 ug/mL
Beside the measured number, compound 3's estimate is 6.6-fold (0.82 log units) above it; the measured number falls inside the stated range.
By their numbers in this assay, from the lowest: compounds 1 and 3 (each within the scatter of the next); then compound 2.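

In this assay, acetyl in place of methyl on an oxygen on a saturated carbon gives a 39-fold lower number from compound 2 to compound 3 (1.60 log units; beyond the scatter) and so reverses most of the loss that came with methoxy: at this position, an oxygen-linked group does not by itself bring the high number of compound 2. Acetoxy and chloro are not separated here, with a 1.3-fold higher number from compound 1 to compound 3 (0.10 log units; within the scatter) lying within the scatter, so the position tolerates these two different groups while methoxy stands apart. Nothing given here explains why methoxy and acetoxy part so widely. From the compounds shown here alone, it remains open whether an amine, a free hydroxyl or a longer acyl chain at this position would stay with chloro and acetoxy or fall with methoxy. Going by these compounds, whether the acetoxy result holds on other cell lines also remains open.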